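From compound 3 to its 3-chlorophenyl relative, compound 4

The source may report more compounds than this note shows. Statements on the series, on what has been measured and on what is new or still open speak of the compounds shown alone.

compound 1 `CC(=O)c1ccc(NC(=O)CSC(=S)N[C@H]2CCOC2=O)cc1` gives > 128000 nM
compound 2 `CCOC(=O)c1ccc(NC(=O)CSC(=S)N[C@H]2CCOC2=O)cc1` gives 60300 nM
compound 3 `O=C(CSC(=S)N[C@H]1CCOC1=O)Nc1ccc(C(=O)/C=C/c2ccccc2)cc1` gives 44300 nM

In a functional assay on MCF7 cells (Homo sapiens) for cytotoxicity, read by MTT assay, with a stated time of 72 h (a higher number here means a weaker inhibitor, a lower number a stronger inhibitor), compound 1 gives > 128000 nM, which is a limit of the assay and not a number. Compound 2 gives 60300 nM and compound 3 gives 44300 nM. These two values cannot be ranked: the measured step is a 1.4-fold lower number from compound 2 to compound 3 (0.13 log units; within the scatter). The two steps that start from the limit are modest but clear of the scatter: an at least 2.1-fold lower number from compound 1 to compound 2 (0.32 log units; beyond the scatter), and an at least 2.8-fold lower number from compound 1 to compound 3 (0.46 log units; beyond the scatter).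

Compound 4 `O=C(CSC(=S)N[C@H]1CCOC1=O)Nc1ccc(C(=O)/C=C/c2cccc(Cl)c2)cc1` has a single change from compound 3: chloro in place of hydrogen on an aromatic carbon. This is chloro in place of hydrogen on an aromatic carbon, which turns phenyl into 3-chlorophenyl. For the measured compounds named here, no measured step tests a chloro group. The measured steps all change the group on a carbonyl carbon, so they bear on this change only indirectly. They suggest that this series in this assay moves little with such changes, so a step beyond the scatter is not expected. The estimated step is a 1.2-fold lower number from compound 3 to compound 4 (0.09 log units; within the scatter), a small expected drop that would not stand out from the scatter. The expected value for compound 4 is 36000 nM, with an estimated range from 15000 nM to 85000 nM.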

Compound 4, half-maximal inhibitory concentration: 11600 nM
The estimate for compound 4 lay 3.1-fold (0.49 log units) above the measured number, outside the stated range (below it).
By their numbers in this assay, from the lowest: compound 4; then compounds 3 and 2 (each within the scatter of the next). At a limit, above all of these: compound 1.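

In this assay, the phenyl ring of the 2-phenylethenyl group turns out to be a place where this series responds: chloro in place of hydrogen gives a 3.8-fold lower number from compound 3 to compound 4 (0.58 log units; beyond the scatter), and this is the first change shown on that ring. Changing the group on the carbonyl carbon had left compound 2 and compound 3 within the scatter of each other, whereas 2-(3-chlorophenyl)ethenyl in place of ethoxy gives a 5.2-fold lower number from compound 2 to compound 4 (0.72 log units; beyond the scatter), which leaves compound 4 with the lowest number of the compounds shown, clear of the scatter from all the others. Compound 1 gives a limit and not a number, so the widest step, an at least 11-fold lower number from compound 1 to compound 4 (1.04 log units; beyond the scatter), fixes only a minimum size: the limit of > 128000 nM in this assay, at which 1 of the 4 values shown sits.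

The compounds shown leave open whether fluoro, methoxy or an amine at the same place on the ring would lower the number as chloro does, or whether this drop is specific to chloro. They also leave open whether chloro elsewhere on the ring would match 3-chlorophenyl, and whether a second chloro would lower the number further.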